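This account rests on a few compounds, and the source may have more. Where it says the series, first, only, none or still open, it means among the compounds named here.

Measured compounds in a physicochemical assay for lipophilicity, using the shake flask method, in phosphate buffer, measured as octanol-water partition, with a stated time of 1 h, at pH 7.4; a lower number here means a more polar compound, a higher number a more lipophilic compound:
compound 1 `CCNC(=O)Nc1cc(Cl)c(-c2cncc(C(=O)O)c2)cn1` gives -1.1;
compound 2 `CCNC(=O)Nc1cc(-c2nc(C(F)(F)F)cs2)c(-c2nc3cccc(C(=O)O)c3s2)cn1` gives 0.73;
compound 3 `CCNC(=O)Nc1cc(-c2cccnc2)c(-c2cncc(C(=O)O)c2)cn1` gives -1.5.

Compound 1 stands second highest of the three, with compound 3 below it and compound 2 well above it. Compound 4 `CCNC(=O)Nc1cc(-c2ccccc2)c(-c2cncc(C(=O)O)c2)cn1` differs from compound 1 in one place: phenyl in place of chloro on an aromatic carbon. For the measured compounds named here, the one measured step that bears on this change is a number 0.40 log units lower from compound 1 to compound 3 (beyond the scatter), where the ring entering was a pyridin-3-yl. Here the entering ring is a six-membered aromatic ring of carbon only, and the expected step, upward rather than downward, moderate in size and beyond the scatter, is estimated as a number 0.60 log units higher from compound 1 to compound 4 (beyond the scatter). Compound 4 is therefore estimated at -0.5, within a range of -1.2 to 0.2.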

Compound 4, distribution coefficient: -0.31
The estimate for compound 4 lay 0.19 log units below the measured number; the range from low to high includes it.
By their numbers in this assay, from the lowest: compound 3; then compound 1; then compound 4; then compound 2.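

Replacing chloro with phenyl gives a number 0.79 log units higher from compound 1 to compound 4 (beyond the scatter) in this assay and so runs opposite to the change from chloro to pyridin-3-yl on this same aromatic carbon. Putting phenyl in place of pyridin-3-yl gives a number 1.19 log units higher from compound 3 to compound 4 (beyond the scatter) as a large step of its own, so the two rings do not behave alike here. Nothing measured here gives a reason for this difference between the two rings. The compounds shown leave open how a saturated ring such as piperidine or a short chain such as methoxy would compare on this carbon. They also leave open whether phenyl carrying an amine would stay closer to compound 4 or to compound 3.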